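From Compound 3 to Compound 4: Expected Microsomal Clearance

The source may report more compounds than this note shows. Statements on the series, on what has been measured and on what is new or still open speak of the compounds shown alone.

Measured compounds:
Compound 1, `CC#C[C@H]1CN(S(=O)(=O)c2ccc(N)nc2)CCN1c1ccc(C(=O)NC)cc1`: 41 mL.min-1.g-1
Compound 2, `CC#C[C@H]1CN(S(=O)(=O)c2ccc(N)nc2)CCN1c1ccc(C(O)(CC#N)C(F)(F)F)cc1`: 57 mL.min-1.g-1
Compound 3, `CC#C[C@H]1CN(S(=O)(=O)c2ccc(N)nc2)CCN1c1ccc(S(=N)(=O)C2CC2)cc1`: 23 mL.min-1.g-1

In an ADME assay (liver) for metabolic stability, with Liver microsome (Rattus norvegicus) as the target, using microsomes and NADPH, with a stated time of 30 min (a higher number here means faster removal of the compound, a lower number slower removal), compound 3 gives 23 mL.min-1.g-1, the lowest of the three numbers. Its gap to compound 1 is small, since the step of a 1.8-fold lower number from compound 1 to compound 3 (0.25 log units; within the scatter) stays within the scatter, whereas the step of a 2.5-fold lower number from compound 2 to compound 3 (0.39 log units; beyond the scatter) lies beyond it. The three measured compounds share one core and differ only at a single aromatic carbon, so every measured step bears on the change now considered: a 1.4-fold higher number from compound 1 to compound 2 (0.14 log units; within the scatter), a 1.8-fold lower number from compound 1 to compound 3 (0.25 log units; within the scatter) and a 2.5-fold lower number from compound 2 to compound 3 (0.39 log units; beyond the scatter). All of these are small, two of them within the scatter.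

Compound 4, `CC#C[C@H]1CN(S(=O)(=O)c2ccc(N)nc2)CCN1c1ccc(C(C)=O)cc1`, differs from compound 3 by a group of 3 heavy atoms (2 carbon, 1 oxygen; no ring) in place of a group of 6 heavy atoms (3 carbon, 1 nitrogen, 1 oxygen, 1 sulfur; one three-membered non-aromatic ring of carbon only), on an aromatic carbon. Among the measured compounds shown here, no measured compound carries an acetyl group, so the change has no direct precedent. Given that replacements at this position have moved the number by modest amounts only, compound 4 is expected to sit close to compound 3, if anything somewhat higher and nearer compound 1, whose value is 41 mL.min-1.g-1. The expected step is a 1.5-fold higher number from compound 3 to compound 4 (0.18 log units; within the scatter), within the scatter. Compound 4 is therefore estimated at 35 mL.min-1.g-1, with a range from 18 mL.min-1.g-1 to 70 mL.min-1.g-1.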

Compound 4, intrinsic clearance in microsomes: 249 mL.min-1.g-1
Compound 4: middle estimate off by 7.1-fold (0.85 log units), on the low side, outside the stated range (above it).
By their numbers in this assay, from the lowest: compounds 3, 1 and 2 (each within the scatter of the next, the first and the last beyond it); then compound 4.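

In this assay the acetyl group shows that the number is far more sensitive to the group on this aromatic carbon than the modest spread among compound 1, compound 2 and compound 3 suggested, giving an 11-fold higher number from compound 3 to compound 4 (1.03 log units; beyond the scatter) and a 4.4-fold higher number from compound 2 to compound 4 (0.64 log units; beyond the scatter) in one change. Even methyl in place of methylamino on a carbonyl carbon gives a 6.1-fold higher number from compound 1 to compound 4 (0.78 log units; beyond the scatter) and so, in this pair, a carbonyl on the ring does not by itself keep the number low. Nothing shown here explains this rise.

On these data alone, it remains open whether the high number belongs to the acetyl group alone or extends to a propanoyl group, a primary amide or a carboxylic acid on the same carbon. As far as these compounds go, it is also open whether an acetyl group would give such a step on a different core.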